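A few compounds are considered here, and "the series" means these few. Any claim that something is new, unique, unknown or untested is made for them only; others in the source may bear on it.

Working notes on the series. Going by the values given here, in a functional assay on HeLa cells (Homo sapiens) for inhibition, read by CCK-8 assay, with a stated time of 72 h, tested at 8 uM (on this read-out higher numbers stand for more inhibition of growth at the one concentration tested and lower numbers for less inhibition of growth), compound 2 (`CCc1ccc(SCc2ccc(C(=O)Nc3ccccc3N)cc2)cc1`) gives 71%, the highest of the three numbers so far. Compound 3 (`Nc1ccccc1NC(=O)/C=C/c1ccc(CSc2cccc3ccccc23)cc1`) gives 22.1%, and compound 1 (`CCc1ccc(SCc2ccc(/C=C/C(=O)Nc3ccccc3N)cc2)cc1`) gives 20.9%. The gap from compound 2 to each of these two compounds lies beyond the scatter.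

Next is compound 4 (`Nc1ccccc1NC(=O)c1ccc(CSc2ccc(F)cc2)cc1`), which differs from compound 2 at a single place: fluoro in place of ethyl on an aromatic carbon. The change lies para to a large group and turns 4-ethylphenyl into 4-fluorophenyl.

Among the compounds with values here, only one measured step bears on this change, and only indirectly. It is a number 1.2 percentage points higher from compound 1 to compound 3 (within the scatter), where naphthalen-1-yl replaces 4-ethylphenyl on a sulfur. That step lies within the scatter, but it was measured on the core of compound 1, not on the core of compound 2, and it involves a different replacement group. Within the data shown here, the data hold no fluoro compound and no replacement of this group on the core of compound 2.

No step beyond the scatter is therefore expected in this assay, although the uncertainty is wide. The expected change is a number 6 percentage points lower from compound 2 to compound 4 (within the scatter). Compound 4 is estimated at 65%, with an expected range of 44% to 82%.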

Compound 4, percent growth inhibition at one concentration: 79.3%
For compound 4 the middle estimate is 14.3 percentage points below the measured one; the measured number falls inside the stated range.
By their numbers in this assay, from the lowest: compounds 1 and 3 (each within the scatter of the next); then compounds 2 and 4 (each within the scatter of the next).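

In this assay, going by these compounds alone, the change from ethyl to fluoro gives a number 8.3 percentage points higher from compound 2 to compound 4 (within the scatter), the first direct reading of this position on the core of compound 2. Measured there, 4-ethylphenyl and 4-fluorophenyl cannot be told apart, even though one heavy atom replaces two, and the high level of growth inhibition seen with compound 2 is kept in compound 4. Nothing at hand gives a reason for this outcome.

The steps at this group now cover two cores, and both a number 1.2 percentage points higher from compound 1 to compound 3 (within the scatter) and the step above lie within the scatter, but each involves a different replacement, so they show no shared rule for the group. Still open, as far as these compounds go, is whether this position stays as undemanding on the core of compound 2 with naphthalen-1-yl, or with an amine, a carboxylic acid or a longer alkyl chain in place of fluoro, and whether compounds that match at the one concentration tested would also match across a range of concentrations.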